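Replacing the Hydroxyamino Urea Terminus with a Fused Aromatic Group

This account rests on a few compounds, and the source may have more. Where it says the series, first, only, none or still open, it means among the compounds named here.

Compounds measured in a functional assay on MCF7 cells (Homo sapiens) for inhibition; a higher number here means a weaker inhibitor, a lower number a stronger inhibitor:
- compound 1, `CC(C)C(NC(=O)NO)C(=O)NC1CCCCC1`: > 100000 nM, a limit of the assay
- compound 2, `CCC(C)C(NC(=O)NO)C(=O)NC1CCCCC1`: > 100000 nM, a limit of the assay
- compound 3, `CCC(C)C(NC(=O)NO)C(=O)NC(c1ccccc1)c1ccccc1`: 17800 nM

Compound 3 is the only one of the three that gives a number; the other two sit at the limit of > 100000 nM in this assay, at which 2 of the 3 values shown sit. Going by the values given here, the one step among the measured compounds, a step that the two limits leave unreadable from compound 1 to compound 2, cannot be read, since both of its ends are limits, and it touches the chain branch, not the terminus. Compound 4, `CCC(C)C(NC(=O)n1nnc2ccccc21)C(=O)NC(c1ccccc1)c1ccccc1`, differs from compound 3 in a different way: a group of 9 heavy atoms (6 carbon, 3 nitrogen; one five-membered aromatic ring with 3 hetero atoms, one six-membered aromatic ring of carbon only) in place of a group of 2 heavy atoms (1 nitrogen, 1 oxygen; no ring), on a carbonyl carbon. The hydroxyamino group leaves and a larger, ring-bearing group enters on that carbonyl carbon. Among the compounds with values here, no measured step bears on this change, so nothing in the data sets its size or direction. Compound 3 stands only moderately far from the assay limit, and a change of this extent at the terminus is expected to move the result at least beyond the scatter, most likely toward weaker inhibition, with a real chance that compound 4 returns only a limit. The estimated step is a 2.0-fold higher number from compound 3 to compound 4 (0.29 log units; within the scatter). For compound 4 the expected value is 35000 nM, within a range from 5000 nM to 150000 nM.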

Compound 4, half-maximal inhibitory concentration: > 100000 nM
Compound 4 was reported as a limit; the forecaster's own chance of this, stated with the estimate: 40%; at least 2.8-fold (0.45 log units) between middle value and limit.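

In this assay, the carbonyl carbon proves to be a place where the result responds: putting the larger, ring-bearing group there in place of hydroxyamino gives an at least 5.6-fold higher number from compound 3 to compound 4 (0.74 log units; beyond the scatter), the only readable step among these compounds. On these data alone, compound 4 gives > 100000 nM, which is a limit of the assay and not a number, so the true size of this step stays unknown and only its direction and minimum are fixed. With this single exchange, the one measured number in the series is lost, and compound 4 now sits at the same limit as compound 1 and compound 2: the limit of > 100000 nM in this assay, at which 3 of the 4 values shown sit.

As far as these compounds go, the step from compound 1 to compound 2 cannot be read, as both of its ends are limits, so the effect of the chain branch stays open. From the compounds shown here alone, it also stays open whether the loss follows from hydroxyamino leaving or from this particular group entering, a question that a small group such as a plain amino or a methoxy group on the same carbonyl carbon could help to separate.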